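Trading an Amide Arm for Chlorine: Expectations for Compound 4

The source may report more compounds than this note shows. Statements on the series, on what has been measured and on what is new or still open speak of the compounds shown alone.

Compound 1, `O=C1Nc2ccccc2/C1=C\C(=O)c1cc(F)cc(F)c1`: 17600 nM
Compound 2, `CC(C)C(=O)Nc1cccc(C(=O)/C=C2/C(=O)Nc3ccccc32)c1`: 8600 nM
Compound 3, `O=C1Nc2ccccc2/C1=C\C(=O)c1ccccc1F`: 17400 nM

All three compounds share one core and differ only in what is attached to the six-membered aromatic ring of carbon only. In a functional assay on SGC-7901 cells (Homo sapiens) for inhibition, read by MTT assay, with a stated time of 72 h (a lower number here means a stronger inhibitor, a higher number a weaker inhibitor), compound 2 gives 8600 nM, the lowest of the three numbers. Compound 3 gives 17400 nM and compound 1 gives 17600 nM; both of these stand a step beyond the usual scatter above compound 2, so compound 2 is the strongest inhibitor shown.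

Compound 4, `O=C1Nc2ccccc2/C1=C\C(=O)c1cccc(Cl)c1`, has not yet been measured. Relative to compound 2 the change is chloro in place of (isopropylcarbonyl)amino on an aromatic carbon. For the measured compounds named here, no two measured compounds differ in a single place, so no measured step speaks directly to this change. What the numbers do show is that compound 1, which carries only halogens, gives 17600 nM, and compound 3, which also carries only halogens, gives 17400 nM, while the amide-bearing compound 2 gives 8600 nM. The step is therefore expected to run toward weaker inhibition, a 1.7-fold higher number from compound 2 to compound 4 (0.24 log units; within the scatter), roughly at the edge of the scatter. Compound 4 is estimated at 15000 nM, in the range 6000 nM to 40000 nM.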

Compound 4, half-maximal inhibitory concentration: 8400 nM
The estimate for compound 4 lay 1.8-fold (0.25 log units) above the measured number; the measured number falls inside the stated range.
By their numbers in this assay, from the lowest: compounds 4 and 2 (each within the scatter of the next); then compounds 3 and 1 (each within the scatter of the next).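

In this assay the exchange of (isopropylcarbonyl)amino for chloro gives a 1.0-fold lower number from compound 2 to compound 4 (0.01 log units; within the scatter) and leaves the two compounds indistinguishable. This is the first pair shown that differs in one place, and it gives a direct reading: on this aromatic carbon, meta to a large group, an arm of six heavy atoms with a hydrogen-bond donor and acceptor can give way to a single chlorine atom with no change beyond the scatter, so the amide arm is not needed to reach this level of inhibition. No measurement available here explains why two such different groups read alike.

Going by these compounds, whether an amine, a carboxylic acid or a longer chain on this same carbon would also read alike remains open. So does the question of how chloro would read on another carbon of this ring.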